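From 3-methylphenyl to 4-methylphenyl on a shared core

This account rests on a few compounds, and the source may have more. Where it says the series, first, only, none or still open, it means among the compounds named here.

Measured in a functional assay on MCF7 cells (Homo sapiens) for antiproliferative activity, read by MTT assay, with a stated time of 72 h; a higher number here means a weaker inhibitor, a lower number a stronger inhibitor:
- compound 1 `COc1ccc(-c2ccc3ncn(-c4cc(OC)c(OC)c(OC)c4)c3c2)cc1F`: 520 nM
- compound 2 `COc1cc(-n2cnc3ccc(-c4cc(F)ccc4F)cc32)cc(OC)c1OC`: 6420 nM
- compound 3 `COc1cc(-n2cnc3ccc(-c4cccc(C)c4)cc32)cc(OC)c1OC`: 360 nM

Two steps fix the standing of compound 3 on these numbers: a 1.4-fold lower number from compound 1 to compound 3 (0.16 log units; within the scatter), and an 18-fold lower number from compound 2 to compound 3 (1.25 log units; beyond the scatter). It thus sits level with compound 1 and well clear of compound 2.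

Compound 4 `COc1cc(-n2cnc3ccc(-c4ccc(C)cc4)cc32)cc(OC)c1OC` carries 4-methylphenyl in place of 3-methylphenyl on an aromatic carbon. Among the compounds with values here, no measured step moves a methyl group, so only the other replacements at this carbon offer guidance. They point both ways: a 1.4-fold lower number from compound 1 to compound 3 (0.16 log units; within the scatter), yet a 12-fold higher number from compound 1 to compound 2 (1.09 log units; beyond the scatter). The substituent at this carbon can therefore matter a great deal, although the two groups exchanged here differ only in where the methyl sits. A small step, none beyond the scatter, is expected, with a slight lean towards a higher number, and a wide range is kept open.

The step expected is a 1.4-fold higher number from compound 3 to compound 4 (0.14 log units; within the scatter). For compound 4 the estimated value is 500 nM, with an expected range of 130 nM to 2200 nM.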

Compound 4, half-maximal inhibitory concentration: 110 nM
Compound 4: middle estimate off by 4.5-fold (0.66 log units), on the high side, and the stated range ends above it.
By their numbers in this assay, from the lowest: compound 4; then compounds 3 and 1 (each within the scatter of the next); then compound 2.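

In this assay, moving the methyl group alone gives a 3.3-fold lower number from compound 3 to compound 4 (0.51 log units; beyond the scatter), so with the same atoms on the ring, the choice between 3-methylphenyl and 4-methylphenyl matters at this carbon. Compound 4 also separates from the two other aryl groups, with a 4.7-fold lower number from compound 1 to compound 4 (0.67 log units; beyond the scatter) and a 58-fold lower number from compound 2 to compound 4 (1.77 log units; beyond the scatter), and it now has the lowest number of the four compounds, whereas compound 3 and compound 1 could not be told apart. Nothing available here explains the difference between the two methyl placements.

The compounds shown leave open whether this gain is specific to the methyl group or would hold for other groups at the same ring position. An ethyl group or a carboxylic acid in place of that methyl would address this question.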